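Oxime ether series: chloro in place of 4-bromophenoxy

The source may report more compounds than this note shows. Statements on the series, on what has been measured and on what is new or still open speak of the compounds shown alone.

compound 1 `Cc1nnsc1CO/N=C/c1c(C)nn(C)c1Oc1ccc(Br)cc1` — 12800 nM
compound 2 `Cc1nnsc1CO/N=C/c1c(C)nn(C)c1Oc1ccc(OC(F)(F)F)cc1` — > 50000 nM (a limit of the assay)
compound 3 `Cc1nnsc1CO/N=C/c1c(C)nn(C)c1Cl` — not yet measured

Among the compounds with values here, in a functional assay on PANC-1 cells (Homo sapiens) for inhibition, read by MTT assay, with a stated time of 48 h (on this read-out lower numbers stand for stronger inhibition and higher numbers for weaker inhibition), compound 1 gives 12800 nM, the only number in the set. For compound 2 this assay reports only a limit, > 50000 nM. Within the data shown here, the one measured step, an at least 3.9-fold higher number from compound 1 to compound 2 (0.59 log units; beyond the scatter), rests on the limit of > 50000 nM in this assay, at which 1 of the 2 values shown sits, and exchanges a substituent on the phenoxy ring. Compound 3 is a different kind of change: chloro in place of 4-bromophenoxy on an aromatic carbon. Among the measured compounds shown here, no measured step removes the whole 4-bromophenoxy group, so the single step from compound 1 to compound 2 gives only a weak guide; it shows that this assay is sensitive to what stands at this position. Working estimate: a 2.0-fold higher number from compound 1 to compound 3 (0.29 log units; within the scatter) is expected, toward weaker inhibition with a real chance of a limit. Compound 3 is therefore estimated at 25000 nM, with a range from 6000 nM to 50000 nM.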

Compound 3, half-maximal inhibitory concentration: 26600 nM
For compound 3 the middle estimate is 1.1-fold (0.03 log units) below the measured one, and the stated range covers the measured number.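

Replacing the whole 4-bromophenoxy group with chloro gives, in this assay, a 2.1-fold higher number from compound 1 to compound 3 (0.32 log units; beyond the scatter). The earlier pair changed only a substituent on the phenoxy ring, whereas this step shows that a measurable number survives at this position without that ring, with compound 3 at 26600 nM. Compound 2 remains a limit of the assay, not a number, so its place relative to the other compounds cannot be fixed: the limit of > 50000 nM in this assay, at which 1 of the 3 values shown sits.

The compounds shown give only the 4-substituted phenoxy groups and chloro at this position, so the response to an amine, a carboxylic acid or a longer alkoxy chain there remains open. Also open, going by these compounds, is whether any group at this position can give a lower number than compound 1 in this assay.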